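This account rests on a few compounds, and the source may have more. Where it says the series, first, only, none or still open, it means among the compounds named here.

In a functional assay on B16 cells (Mus musculus) for antiproliferative activity, read by MTT assay, with a stated time of 24 h (on this read-out higher numbers stand for weaker inhibition and lower numbers for stronger inhibition), compound 1 `COc1cc(OC)c(-c2coc3cc(OCc4ccc(F)cc4)ccc3c2=O)cc1OC` gives 1120 nM, compound 2 `COc1cc(OC)c(-c2coc3cc(OCc4ccc(Br)cc4)ccc3c2=O)cc1OC` gives 1180 nM and compound 3 `COc1cc(OC)c(-c2coc3cc(OCc4ccccc4C(F)(F)F)ccc3c2=O)cc1OC` gives 8550 nM, the highest number of the three and so the weakest inhibition. Compound 4 `COc1cc(OC)c(-c2coc3cc(OCc4cccc(F)c4)ccc3c2=O)cc1OC` carries 3-fluorophenyl in place of 2-(trifluoromethyl)phenyl on a saturated chain carbon bound to an oxygen on an aromatic ring. For the measured compounds named here, two measured steps bear on this change, a 7.6-fold higher number from compound 1 to compound 3 (0.88 log units; beyond the scatter) and a 7.2-fold higher number from compound 2 to compound 3 (0.86 log units; beyond the scatter), and both lie beyond the scatter. Swapping bromo for fluoro gave a 1.1-fold higher number from compound 1 to compound 2 (0.02 log units; within the scatter), which lies within it. Going by the values given here, no measured compound carries 3-fluorophenyl, so this is an inference from those steps. In this assay, the expected change is a reversal of similar size, a 5.7-fold lower number from compound 3 to compound 4 (0.76 log units; beyond the scatter). Compound 4 is estimated at 1500 nM, with an expected range of 600 nM to 4500 nM.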

Compound 4, half-maximal inhibitory concentration: 2440 nM
Estimate against measurement, compound 4: 1.6-fold (0.21 log units) below, and the stated range covers the measured number.
By their numbers in this assay, from the lowest: compounds 1 and 2 (each within the scatter of the next); then compound 4; then compound 3.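

this assay shows that 2-(trifluoromethyl)phenyl is not the only change here that moves the number: 3-fluorophenyl recovers part of the loss (a 3.5-fold lower number from compound 3 to compound 4 (0.54 log units; beyond the scatter)) but stays apart from the other two compounds (a 2.1-fold higher number from compound 2 to compound 4 (0.32 log units; beyond the scatter); a 2.2-fold higher number from compound 1 to compound 4 (0.34 log units; beyond the scatter)). The last step keeps the fluorine and changes only 4-fluorophenyl to 3-fluorophenyl, so where the group sits on the ring counts as well as which group it is. Nothing available explains these shifts. From the compounds shown here alone, what an amine or a longer chain in place of the benzyl group would do remains open.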